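Adding a Trifluoromethyl Group to Compound 3

The source may report more compounds than this note shows. Statements on the series, on what has been measured and on what is new or still open speak of the compounds shown alone.

Measured compounds:
compound 1 `Cc1ccc(-c2cn(-c3ccc(CN4CCN(C)CC4)cc3)nn2)cc1Nc1nccc(-c2cccnc2)n1`: 4150 nM
compound 2 `Cc1ccc(-n2cc(-c3ccc(CN4CCN(C)CC4)c(C(F)(F)F)c3)nn2)cc1Nc1nccc(-c2cccnc2)n1`: 8180 nM
compound 3 `Cc1ccc(-c2nnc(-c3ccc(CN4CCN(C)CC4)cc3)o2)cc1Nc1nccc(-c2cccnc2)n1`: 7630 nM

In an ADME assay on HEK-293T cells (Homo sapiens) for inhibition (a higher number here means that more compound is tolerated, a lower number that less compound is tolerated), compound 3 stands second highest of the three numbers; compound 2 is nearest to it and compound 1 furthest, yet both gaps lie within the scatter of repeated measurements. Compound 4 `Cc1ccc(-c2nnc(-c3ccc(CN4CCN(C)CC4)c(C(F)(F)F)c3)o2)cc1Nc1nccc(-c2cccnc2)n1` differs from compound 3 by trifluoromethyl in place of hydrogen on an aromatic carbon. Within the data shown here, no pair among the measured compounds differs in one place only, so no single step is known. Compound 2, which also carries a trifluoromethyl group, and compound 3 give numbers within the scatter of each other. Compound 4 is therefore expected to show no step beyond the scatter, a 1.1-fold higher number from compound 3 to compound 4 (0.05 log units; within the scatter). Compound 4 is estimated at 8500 nM with a range from 4000 nM to 18000 nM.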

Compound 4, half-maximal cytotoxic concentration: 2170 nM
The estimate for compound 4 lay 3.9-fold (0.59 log units) above the measured number, and the stated range ends above it.
By their numbers in this assay, from the lowest: compounds 4, 1, 3 and 2 (each within the scatter of the next, the first and the last beyond it).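

In this assay, among these compounds, trifluoromethyl in place of hydrogen on an aromatic carbon, ortho to a (4-methylpiperazin-1-yl)methyl group, gives a 3.5-fold lower number from compound 3 to compound 4 (0.55 log units; beyond the scatter) and so provides the first single-change step. It shows that this position is sensitive to the change, with less compound tolerated once trifluoromethyl is present. No available evidence accounts for this step. Going by these compounds, whether a chlorine atom or a methoxy group at the same place would give a step of similar size remains open. Also open, on these data alone, is whether the same change would have a like effect on the core of compound 1.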